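Two Chlorinated Sulfonamides and a Dichloro Analogue

This account rests on a few compounds, and the source may have more. Where it says the series, first, only, none or still open, it means among the compounds named here.

Measured so far:
compound 1: `COc1ccc(S(=O)(=O)NC2=NCCN2C(=S)SN2CCn3c2nsc3=S)cc1OC` — >= 20000 nM
compound 2: `O=S(=O)(NC1=NCCN1C(=S)SN1CCn2c1nsc2=S)c1ccccc1Cl` — >= 20000 nM

In a functional assay on KYSE-510 cells (Homo sapiens) for antiproliferative activity, read by crystal violet staining, with a stated time of 96 h (on this read-out lower numbers stand for stronger inhibition of growth and higher numbers for weaker inhibition of growth), compound 1 gives only a limit of the assay, >= 20000 nM. In this assay compound 2 likewise gives only a limit, >= 20000 nM. The change a step that the two limits leave unreadable from compound 1 to compound 2 therefore cannot be read in size, because both values sit at the limit of >= 20000 nM in this assay, at which 2 of the 2 values shown sit. Compound 3, `O=S(=O)(NC1=NCCN1C(=S)SN1CCn2c1nsc2=S)c1ccc(Cl)c(Cl)c1`, differs from compound 2 in one place: 3,4-dichlorophenyl in place of 2-chlorophenyl on a sulfonyl sulfur. Within the data shown here, no measured step shows how the 3,4-dichlorophenyl group shifts growth inhibition. Among the measured compounds shown here, the one step that is available is unreadable in size because both of its values sit at the limit of >= 20000 nM in this assay, at which 2 of the 2 values shown sit. The expectation for compound 3 is thus another limit, with no step beyond the scatter. Compound 3 is estimated at 20000 nM, with a range from 8000 nM to 50000 nM. The expected step is a number no higher from compound 2 to compound 3 (the limit leaves the size open).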

Compound 3, concentration for 50% growth inhibition: >= 20000 nM
Compound 3 was reported as a limit; the forecaster's own chance of this, stated with the estimate: 75%; the middle value lies on the limit itself.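

In this assay, compound 3 also gives only a limit, so the steps to it from compound 1 and compound 2 cannot be read in size: the limit of >= 20000 nM in this assay, at which 3 of the 3 values shown sit.

The compounds shown leave open whether the 3,4-dimethoxyphenyl, 2-chlorophenyl and 3,4-dichlorophenyl groups differ at all in their effect on growth inhibition.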